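Shifting a chlorine atom: from compound 2 to compound 4

The compounds below may be only part of what the source reports. "The series", "measured", "known", "first", "only" and "open" are said of these compounds alone.

Among the measured compounds shown here, in an ADME assay on HEL cells (Homo sapiens) for cytotoxicity (a lower number here means that less compound is tolerated, a higher number that more compound is tolerated), compound 2 `O=C(COc1cccc2ccccc12)N/N=C/c1ccccc1Cl` gives 62.7 ug/mL, the highest of the three numbers measured so far. Compound 1 `COc1ccc(/C=N/NC(=O)COc2cccc3ccccc23)cc1OC` gives 52.6 ug/mL, a gap from compound 2 that lies within the scatter. Compound 3 `C/C(=N\NC(=O)COc1cccc2ccccc12)c1cccc([N+](=O)[O-])c1` gives 10.5 ug/mL, a gap that lies beyond the scatter. Compound 4 `O=C(COc1cccc2ccccc12)N/N=C/c1cccc(Cl)c1` has not yet been tested; it differs from compound 2 only in 3-chlorophenyl in place of 2-chlorophenyl on a carbon with a double bond to nitrogen. For the measured compounds named here, no measured pair in this set shows what such a change does to the read-out, so the expectation rests on the small size of the change and on the number for compound 2. The expected step is a 1.1-fold lower number from compound 2 to compound 4 (0.06 log units; within the scatter), none beyond the scatter. Compound 4 is therefore estimated at 55 ug/mL, with a range from 30 ug/mL to 100 ug/mL.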

Compound 4, half-maximal cytotoxic concentration: 58.6 ug/mL
Estimate against measurement, compound 4: 1.1-fold (0.03 log units) below; measured number inside the range.
By their numbers in this assay, from the lowest: compound 3; then compounds 1, 4 and 2 (each within the scatter of the next).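

In this assay, among the compounds shown here, shifting the chlorine gives a 1.1-fold lower number from compound 2 to compound 4 (0.03 log units; within the scatter) and provides the first step in this set that changes one place only. At this position on a carbon with a double bond to nitrogen, the read-out therefore does not separate 2-chlorophenyl from 3-chlorophenyl. No measurement here offers an explanation for this match. From the compounds shown here alone, whether an amine or a carboxylic acid in place of the chlorine would also leave the number within the scatter remains open. Also open, going by these compounds, is what a longer chain at this position would do.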